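Swapping a bromophenyl for a dichlorophenyl in cytotoxicity

The source may hold more compounds than are shown below. What is called first, only, known or untested is meant among the compounds shown, and "the series" means these compounds.

Compound 1, `COc1cccc(/C=C2\CCC/C(=C\c3ccccc3Br)C2=O)c1OC`: in an ADME assay on NHDF cells (Homo sapiens) for cytotoxicity, read by MTT assay, with a stated time of 72 h (a higher number here means a weaker inhibitor, a lower number a stronger inhibitor), compound 1 gives > 50000 nM, which is a limit of the assay and not a number.
Compound 2, `COc1cccc(/C=C2\CCC/C(=C\c3cc(Cl)cc(Cl)c3)C2=O)c1OC`: in this assay compound 2 gives 21600 nM.
Compound 3, `COc1ccc(/C=C2\CCC/C(=C\c3cccc(Br)c3)C2=O)cc1OC`: in this assay compound 3 gives 12400 nM.

Compound 3 holds the lowest of the two numbers. Compound 2 is nearest, and the gap between them lies within the scatter of this assay, so the two cannot be ordered. Compound 1 sits at a limit, (the limit of > 50000 nM in this assay, at which 1 of the 3 values shown sits), and adds no number.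

Compound 4, `COc1ccc(/C=C2\CCC/C(=C\c3cc(Cl)cc(Cl)c3)C2=O)cc1OC`, differs from compound 3 in one place: 3,5-dichlorophenyl in place of 3-bromophenyl on a double-bonded chain carbon bound to a double-bonded ring carbon. Among the measured compounds shown here, the one measured step that resembles it is an at least 2.3-fold lower number from compound 1 to compound 2 (0.36 log units; beyond the scatter). There a 3,5-dichlorophenyl also entered in place of a bromophenyl, and the number fell. As far as these compounds go, that step starts from a limit, so its true size is unknown, and both the bromophenyl it replaced and the shared core differ from those of compound 3. A lowering of roughly that size, or none beyond the scatter, is therefore expected. The expected step is a 1.6-fold lower number from compound 3 to compound 4 (0.19 log units; within the scatter). Compound 4 is estimated at 8000 nM, within 3000 nM to 25000 nM.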

Compound 4, half-maximal inhibitory concentration: 8300 nM
Estimate against measurement, compound 4: 1.0-fold (0.02 log units) below; measured number inside the range.
By their numbers in this assay, from the lowest: compounds 4, 3 and 2 (each within the scatter of the next, the first and the last beyond it). At a limit, above all of these: compound 1.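

With a real number at both ends, putting 3,5-dichlorophenyl in place of 3-bromophenyl on a double-bonded chain carbon bound to a double-bonded ring carbon gives a 1.5-fold lower number from compound 3 to compound 4 (0.17 log units; within the scatter) in this assay. On the core shared by these two compounds, then, the two groups cannot be told apart by this read-out, even though the entering group has one more heavy atom and two chlorines instead of one bromine. Compound 1 stands at a limit, so the only other step bringing in this group, taken on a different core, has no known size: the limit of > 50000 nM in this assay, at which 1 of the 4 values shown sits.

As far as these compounds go, it remains open whether a phenyl carrying an amine or a carboxylic acid at this place would give a number beyond the scatter of these two. The compounds shown also leave open whether a simple phenyl with no halogen would differ from either.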